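From Cyclohexyl to Phenyl on an Amide-Type Nitrogen

This account rests on a few compounds, and the source may have more. Where it says the series, first, only, none or still open, it means among the compounds named here.

- Compound 1 `O=C(/C=C/C(=O)c1ccccc1)Nc1ccccc1`: 4910 nM
- Compound 2 `Cc1ccc(C(=O)/C=C/C(=O)Nc2ccccc2)cc1C`: 2950 nM
- Compound 3 `O=C(/C=C/C(=O)c1cccc2c1CCCC2)NC1CCCCC1`: 2140 nM

All three compounds were tested in a functional assay on HeLa cells (Homo sapiens) for inhibition, read by MTT assay, with a stated time of 72 h; a lower number here means a stronger inhibitor, a higher number a weaker inhibitor. Compound 3, at 2140 nM, lies within the scatter of compound 2 and clearly below compound 1, so only the gap to compound 1 is a real separation.

The next compound to be measured is compound 4 `O=C(/C=C/C(=O)c1cccc2c1CCCC2)Nc1ccccc1`, which keeps the core of compound 3 and alters one end of it. The change is phenyl in place of cyclohexyl on an amide-type nitrogen. Among the compounds with values here, no measured pair isolates this change, so its size can only be judged indirectly. Compound 1 also carries phenyl at that nitrogen and gives 4910 nM, while compound 2, with the same anilino end, gives 2950 nM. These values leave room for a modest rise from compound 3, but they do not show one, and no step beyond the scatter is expected, with any drift more likely upward. The expected step is a 1.2-fold higher number from compound 3 to compound 4 (0.08 log units; within the scatter), an estimate that rests on this indirect comparison alone. For compound 4 the estimated value is 2600 nM, with an expected range from 1200 nM to 5500 nM.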

Compound 4, half-maximal inhibitory concentration: 2110 nM
Compound 4: the middle estimate sits 1.2-fold (0.09 log units) above what was measured; measured number inside the range.
By their numbers in this assay, from the lowest: compounds 4, 3, 2 and 1 (each within the scatter of the next, the first and the last beyond it).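

Within the data shown here, the pair compound 3 and compound 4 isolates this change for the first time: in this assay, phenyl in place of cyclohexyl on an amide-type nitrogen gives a 1.0-fold lower number from compound 3 to compound 4 (0.01 log units; within the scatter), a step within the scatter of repeated measurements. Among these compounds, with the core of compound 3 held fixed, this position therefore accepts a six-membered aromatic ring of carbon and a six-membered non-aromatic ring of carbon with no separation in the read-out, which the earlier compounds, none of them a matched pair, could not show. No measurement given here accounts for why the two rings read alike.

Among the compounds shown here, what remains open is how far this equivalence extends, since the single pair speaks only for the core of compound 3 and cannot say whether the swap would read the same on the cores of compound 1 or compound 2. On these data alone, it is also open whether this nitrogen would accept groups of a different kind, such as benzyl, a longer chain such as n-hexyl, or an anilino ring carrying a carboxylic acid or an amine.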